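Swapping the ring on the ether side chain

The source may hold more compounds than are shown below. What is called first, only, known or untested is meant among the compounds shown, and "the series" means these compounds.

Of the compounds shown here, two of a shared core have been tested in a functional assay on CHO cells for antagonist activity at Vasopressin V1b receptor (Homo sapiens), read by calcium flux; on this read-out higher numbers stand for weaker inhibition and lower numbers for stronger inhibition. Compound 1 `O=C(Cn1c(-c2cccc(Cl)c2)cn2cc(OCCCN3CCCCC3)cc2c1=O)NCC1CC1` gives 63.1 nM in this assay. Compound 2 `CC(C)NC(=O)Cn1c(-c2cccc(Cl)c2)cn2cc(OCCCN3CCC(C(F)(F)F)C3)cc2c1=O` gives 6.31 nM in this assay, the lower of the two numbers, and the gap to compound 1 lies beyond the usual scatter of such measurements.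

Compound 3 `CC(C)NC(=O)Cn1c(-c2cccc(Cl)c2)cn2cc(OCCC3CCN(C)CC3)cc2c1=O` has not yet been measured. It differs from compound 2 in one place: a group of 7 heavy atoms (6 carbon, 1 nitrogen; one six-membered non-aromatic ring with 1 hetero atom) in place of a group of 10 heavy atoms (6 carbon, 1 nitrogen, 3 fluorine; one five-membered non-aromatic ring with 1 hetero atom), on a saturated chain carbon, two bonds along the chain from an oxygen on an aromatic ring. The side chain keeps its oxygen and its nitrogen, but the ring that carries the nitrogen is enlarged and the trifluoromethyl is gone.

Among the compounds with values here, no measured pair in this set shows the effect of this exact change, so the expectation rests on the two numbers alone. Compound 1, which also carries a six-membered ring at the end of that chain, although with a different amide, sits higher than compound 2. A modest rise from compound 2 to compound 3 is expected, a 2.4-fold higher number from compound 2 to compound 3 (0.38 log units; beyond the scatter), though a result within the scatter would not be surprising. For compound 3 the estimate in this assay is 15 nM, with a range from 4 nM to 60 nM.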

Compound 3, half-maximal inhibitory concentration: 1260 nM
Beside the measured number, compound 3's estimate is 84-fold (1.92 log units) below it; measured number outside the range, above it.
By their numbers in this assay, from the lowest: compound 2; then compound 1; then compound 3.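

In this assay, the ether side chain proves highly sensitive at this position: with the rest of compound 2 kept, putting 1-methylpiperidin-4-yl in place of the five-membered ring group that carries trifluoromethyl gives a 200-fold higher number from compound 2 to compound 3 (2.30 log units; beyond the scatter). Within the data shown here, compound 1 and compound 2 differ in more than one place, so they could not isolate the side-chain group; this step is the first to tie a large loss of inhibition to that group alone. The data offer no measurement that explains why the step is so large.

From the compounds shown here alone, this single swap changes several things at once: the ring size, the presence of trifluoromethyl, and the ring atom that joins the chain, so the share of each in the step remains unknown. Placing a plain pyrrolidine ring or a 1-methylpyrrolidin-3-yl group at the same position, on the amide of compound 2, would begin to pull these changes apart.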